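The source may hold more compounds than are shown below. What is called first, only, known or untested is meant among the compounds shown, and "the series" means these compounds.

Measured compounds:
compound 1 `O=C(Nc1ccccc1O)c1cccc(N2C(=O)c3ccccc3C2=O)c1` gives 77 nM in an in vitro functional assay on HEK293-A cells for antagonist activity at metabotropic glutamate receptor 5 (Rattus norvegicus), read by calcium flux; a higher number here means a weaker inhibitor, a lower number a stronger inhibitor;
compound 2 `COc1ccccc1C(=O)Nc1cccc(NC(=O)c2cccc(F)c2)c1` gives 6480 nM in this assay;
compound 3 `O=C(Nc1cccc(NC(=O)c2cccc(Cl)c2)c1)c1cccc(F)c1` gives > 30000 nM in this assay, which is a limit of the assay and not a number, one of the values sitting at the limit of > 30000 nM in this assay, at which 1 of the 3 values shown sits.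

Among the two numbers, compound 1 holds the lowest; the nearest number, that of compound 2, stands far above it, beyond the scatter. Among the compounds with values here, the single measured step, an at least 4.6-fold higher number from compound 2 to compound 3 (0.66 log units; beyond the scatter), replaces one group on a carbonyl carbon with another and is at least modest in size. It does not touch the part of the molecule that changes next, so it bears only indirectly on what follows.

Compound 4 `O=C(Nc1cccc(O)c1)c1cccc(N2C(=O)c3ccccc3C2=O)c1` differs from compound 1 by 3-hydroxyphenyl in place of 2-hydroxyphenyl on an amide-type nitrogen. Within the data shown here, no measured pair shows what moving the hydroxyl from one position of that ring to another does in this assay, so the expectation rests on compound 1 alone, at 77 nM, with a wide allowance for either direction. A modest rise in the number, that is a somewhat weaker inhibitor, is expected: a 3.9-fold higher number from compound 1 to compound 4 (0.59 log units; beyond the scatter). Compound 4 is therefore estimated at 300 nM, within a range from 80 nM to 1500 nM.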

Compound 4, half-maximal inhibitory concentration: 7790 nM
Beside the measured number, compound 4's estimate is 26-fold (1.41 log units) below it, outside the stated range (above it).
By their numbers in this assay, from the lowest: compound 1; then compounds 2 and 4 (each within the scatter of the next). At a limit, above all of these: compound 3.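

In this assay, the group on the amide-type nitrogen proves highly sensitive to a change that leaves its atoms untouched: 3-hydroxyphenyl in place of 2-hydroxyphenyl gives a 100-fold higher number from compound 1 to compound 4 (2.01 log units; beyond the scatter) on the same core, a large step between two groups with the same atoms and the same counts of hydrogen-bond donors and acceptors. The only earlier step concerned a group on a carbonyl carbon in another series, so this is the first reading at this position, and it shows that the low number of compound 1 does not follow from having a hydroxyl on that ring but goes with the 2-hydroxyphenyl arrangement in particular. Nothing available here accounts for why the two groups differ so widely.

Whether the hydroxyl itself is required remains open, since the compounds shown do not say how the number would move with an amine or a methyl ether in its place, or with a plain phenyl group on that nitrogen. Within the data shown here, how the core of compound 1 contributes on its own also stays undecided, as only this one change to it can be read.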